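Moving the aryl group attached through an oxygen

The compounds below may be only part of what the source reports. "The series", "measured", "known", "first", "only" and "open" are said of these compounds alone.

Three compounds with the same core and the same acid-bearing side chain have been measured in an assay for inhibition of Thromboxane-A synthase (Homo sapiens), using microsomes; a higher number here means a weaker inhibitor, a lower number a stronger inhibitor. Compound 1 `O=C(O)CC/C=C\CC1COC(c2ccccc2Cl)OC1c1cccnc1` gives 48 nM. Compound 2 `O=C(O)CC/C=C\CC1COC(c2ccsc2)OC1c1cccnc1` gives 500 nM; the only single-point step among these three, a 10-fold higher number from compound 1 to compound 2 (1.02 log units; beyond the scatter), shows how strongly a swap of the aromatic group on the core can move the number. Compound 3 `CSc1ccc(OC(C)(C)C2OCC(C/C=C\CCC(=O)O)C(c3cccnc3)O2)c([N+](=O)[O-])c1` gives 22 nM, the lowest of the three numbers and therefore the strongest inhibitor so far, with compound 1 nearest and compound 2 furthest away.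

Compound 4 `CSc1ccccc1OC(C)(C)C1OCC(C/C=C\CCC(=O)O)C(c2cccnc2)O1` differs from compound 3 at the aromatic group hanging from the oxygen: a group of 8 heavy atoms (7 carbon, 1 sulfur; one six-membered aromatic ring of carbon only) in place of a group of 11 heavy atoms (7 carbon, 1 nitrogen, 2 oxygen, 1 sulfur; one six-membered aromatic ring of carbon only), on an oxygen on a saturated carbon. For the measured compounds named here, no measured step covers exactly this kind of exchange; the only step on record changes an aromatic group sitting directly on a saturated ring carbon, not one attached through an oxygen, so it serves only as a rough guide to how much such swaps can matter in this assay. The change here removes the nitro group and keeps a methylsulfanyl-bearing benzene ring, so a modest step in this assay toward a higher number is expected, possibly within the scatter. The estimated step from compound 3 to compound 4 is a 1.8-fold higher number from compound 3 to compound 4 (0.26 log units; within the scatter). Compound 4 is therefore expected to give about 40 nM in this assay, most likely between 12 nM and 150 nM.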

Compound 4, half-maximal inhibitory concentration: 36 nM
Compound 4: middle estimate off by 1.1-fold (0.05 log units), on the high side; the range from low to high includes it.
By their numbers in this assay, from the lowest: compounds 3, 4 and 1 (each within the scatter of the next, the first and the last beyond it); then compound 2.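

In this assay, putting 2-(methylsulfanyl)phenyl on the oxygen in place of the larger nitro-bearing aromatic group gives a 1.6-fold higher number from compound 3 to compound 4 (0.21 log units; within the scatter), so the nitro group can go without a change that this assay can distinguish from scatter. This is the first step shown for an aromatic group attached through the oxygen, and it stays within the scatter, whereas a 10-fold higher number from compound 1 to compound 2 (1.02 log units; beyond the scatter), for a swap of the aromatic group on a saturated ring carbon, lies beyond it. Nothing measured here explains the result or shows what either group contributes.

Compound 3 and compound 4 both carry a methylsulfanyl group on their benzene ring, which leaves open whether that group matters at all, a question that a plain phenyl ring or a methoxy group in its place could address. Also open, from the compounds shown here alone, is whether the number would hold with a more different group on that ring, such as an amine or a carboxylic acid, since one step cannot show how far this position tolerates change.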